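Moving a Methoxy Group in an Antiproliferative Series

The compounds below may be only part of what the source reports. "The series", "measured", "known", "first", "only" and "open" are said of these compounds alone.

Compound 1 `Cn1cc(-c2ccccc2Oc2ccccc2)c2cc(C(=O)NCCCC(=O)NO)[nH]c2c1=O`: 380 nM
Compound 2 `CC(C)Oc1ccc(C(C)(C)O)cc1-c1cn(C)c(=O)c2[nH]c(C(=O)NCc3ccc(C(=O)Nc4ccccc4N)cc3)cc12`: 40 nM
Compound 3 `COc1cccc(-c2cn(C)c(=O)c3[nH]c(C(=O)NCc4ccc(C(=O)Nc5ccccc5N)cc4)cc23)c1`: 250 nM

All three values come from a functional assay on MV4-11 cells (Homo sapiens) for antiproliferative activity, read by CCK-8 assay, with a stated time of 72 h; a higher number here means a weaker inhibitor, a lower number a stronger inhibitor. Compound 3, at 250 nM, has the second highest of the three numbers. Its gap to compound 1 lies within the scatter, so these two cannot be told apart. Compound 2 has a lower number, and that gap lies beyond the scatter.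

The next compound to be tested is compound 4 `COc1ccc(-c2cn(C)c(=O)c3[nH]c(C(=O)NCc4ccc(C(=O)Nc5ccccc5N)cc4)cc23)cc1`. It has the same atoms as compound 3, joined differently, with 4-methoxyphenyl in place of 3-methoxyphenyl on an aromatic carbon.

Among the measured compounds shown here, no two measured compounds differ in only one place, so the data offer no direct guide to the size of this change. With the same group simply joined differently, no shift beyond the scatter is expected, and no direction is clearly favoured. The expected change is a 1.1-fold lower number from compound 3 to compound 4 (0.06 log units; within the scatter). The range stays wide, as compound 2, which carries different groups on that aromatic ring, reaches 40 nM. The estimated value for compound 4 is 220 nM, with an expected range of 80 nM to 600 nM.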

Compound 4, half-maximal inhibitory concentration: 320 nM
Compound 4: middle estimate off by 1.5-fold (0.16 log units), on the low side; the measured number falls inside the stated range.
By their numbers in this assay, from the lowest: compound 2; then compounds 3, 4 and 1 (each within the scatter of the next).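

In this assay, among the compounds shown here, swapping 3-methoxyphenyl for 4-methoxyphenyl gives a 1.3-fold higher number from compound 3 to compound 4 (0.11 log units; within the scatter), the first direct comparison in which only one thing changes at this aromatic carbon. The two compounds therefore cannot be told apart, and in this pair, relocating the methoxy group on the attached ring produces no shift that this measurement can resolve. No supporting measurement bears on this result, so the data give no explanation for it.

From the compounds shown here alone, what remains open is whether a different group on that ring, such as an amine or a carboxylic acid in place of the methoxy group, would move the number beyond the scatter. Compound 2 cannot settle this, since it differs from compound 3 and compound 4 in more than one place, and what any one of its ring groups contributes when compound 2 gives 40 nM stays unresolved.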